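A few compounds are considered here, and "the series" means these few. Any claim that something is new, unique, unknown or untested is made for them only; others in the source may bear on it.

Measured compounds:
compound 1 `CC(=O)N1CCc2c(c(-c3ccc(C(F)(F)F)cc3)nn2CC(O)CN2CCC(c3csc4cc(F)ccc34)CC2)C1`, 290 nM in an assay on isolated protein for inhibition of cathepsin S (Homo sapiens); on this read-out higher numbers stand for weaker inhibition and lower numbers for stronger inhibition
compound 2 `CS(=O)(=O)N1CCc2c(c(-c3ccc(C(F)(F)F)cc3)nn2CC(O)CN2CCC(c3csc4cc(F)ccc34)CC2)C1`, 180 nM in this assay

Within the data shown here, compound 2 has the lowest of the two numbers in this assay; the nearest is compound 1, and the only measured step, a 1.6-fold lower number from compound 1 to compound 2 (0.21 log units; within the scatter), lies within the scatter. Compound 3 `CS(=O)(=O)N1CCc2c(c(-c3ccc(C(F)(F)F)cc3)nn2CC(O)CN2CCC(c3c[nH]c4ccc(C#N)cc34)CC2)C1` differs from compound 2 by 5-cyano-1H-indol-3-yl in place of 6-fluoro-1-benzothiophen-3-yl on a saturated ring carbon. Among the measured compounds shown here, no measured step touches this part of the shared core, so no direction can be read from the data. The expectation for compound 3 in this assay is therefore a step of no change at the digits printed from compound 2 to compound 3 (within the scatter), with wide uncertainty. The estimate for compound 3 is 180 nM, in the range 50 nM to 700 nM.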

Compound 3, half-maximal inhibitory concentration: 21 nM
For compound 3 the middle estimate is 8.6-fold (0.93 log units) above the measured one; measured number outside the range, below it.
By their numbers in this assay, from the lowest: compound 3; then compounds 2 and 1 (each within the scatter of the next).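

Unlike the change on the ring amine nitrogen, a 1.6-fold lower number from compound 1 to compound 2 (0.21 log units; within the scatter), the change on the saturated ring carbon moves the number in this assay beyond the scatter. With 5-cyano-1H-indol-3-yl in place of 6-fluoro-1-benzothiophen-3-yl, this position gives an 8.6-fold lower number from compound 2 to compound 3 (0.93 log units; beyond the scatter), so it is the more responsive of the two places changed so far. No evidence is available that accounts for this step.

Going by these compounds, whether the step follows the nitrile or the indole itself stays open, since both enter together. An unsubstituted 1H-indol-3-yl or a 6-fluoro-1H-indol-3-yl on the same carbon would separate the two.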